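Adding a Fluoro Group to Compound 1

The compounds below may be only part of what the source reports. "The series", "measured", "known", "first", "only" and "open" are said of these compounds alone.

Compound 1 `c1ccc(-c2nn(-c3ccccc3)cc2-c2nc3ccccc3[nH]2)cc1` is the starting point. For the measured compounds named here, in a functional assay on A549 cells (Homo sapiens) for antiproliferative activity, read by MTT assay, with a stated time of 48 h (a higher number here means a weaker inhibitor, a lower number a stronger inhibitor), compound 1 gives 2710 nM, the lower of the two numbers measured so far. Its one measured relative, compound 2 `FC(F)(F)c1ccc2[nH]c(-c3cn(-c4ccccc4)nc3-c3ccccc3)nc2c1`, gives 5930 nM in this assay.

Compound 3 `Fc1ccc(-c2nn(-c3ccccc3)cc2-c2nc3ccccc3[nH]2)cc1` has not been measured yet. It differs from compound 1 in one place: fluoro in place of hydrogen on an aromatic carbon. This is fluoro in place of hydrogen on an aromatic carbon, so a phenyl becomes a 4-fluorophenyl, para to a large group.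

Going by the values given here, only one measured step bears on this change: a 2.2-fold higher number from compound 1 to compound 2 (0.34 log units; beyond the scatter). That modest step came with trifluoromethyl in place of hydrogen on an aromatic carbon. It shows that one such swap can shift the number a little, but it involves a different group and cannot set a direction for fluoro. No step beyond the scatter is therefore expected in this assay. The expected step is a 1.0-fold lower number from compound 1 to compound 3 (0.02 log units; within the scatter). For compound 3 the estimated value is 2600 nM, with an expected range of 1100 nM to 6000 nM.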

Compound 3, half-maximal inhibitory concentration: 1510 nM
Beside the measured number, compound 3's estimate is 1.7-fold (0.24 log units) above it; measured number inside the range.
By their numbers in this assay, from the lowest: compounds 3 and 1 (each within the scatter of the next); then compound 2.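

In this assay, putting fluoro in place of hydrogen, which turns a phenyl into a 4-fluorophenyl, gives a 1.8-fold lower number from compound 1 to compound 3 (0.25 log units; within the scatter), so compound 1 and compound 3 cannot be told apart. For the compounds shown here, this is the first reading at this position, on a six-membered aromatic ring of carbon only and para to a large group, and it shows that a single fluorine can sit there without a shift that stands clear of the usual scatter. Going by these compounds alone, the only earlier step, a 2.2-fold higher number from compound 1 to compound 2 (0.34 log units; beyond the scatter), came with a different group, trifluoromethyl, at a different place, so it said nothing about this position. No measurement shown here offers an explanation for this result.

From the compounds shown here alone, whether a larger or different group at this same position, such as a methoxy group, an amine or a carboxylic acid, would also leave the number close to that of compound 1 remains open. One fluoro compound also gives no trend, and it leaves open how fluoro would fare at other places on this ring or on the rest of the shared core.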